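Replacing the bromo group of compound 1 with a tetrazolyl

The source may report more compounds than this note shows. Statements on the series, on what has been measured and on what is new or still open speak of the compounds shown alone.

Compound 1 `CCC(C)n1ncn(-c2ccc(N3CCN(c4ccc(OC[C@@H]5CO[C@@](CBr)(c6ccc(Cl)cc6Cl)O5)cc4)CC3)cc2)c1=O` is the reference point of this pair. In a functional assay on HUVEC cells (Homo sapiens), read by scintillation counting and thymidine incorporation, with a stated time of 24 h (a higher number here means a weaker inhibitor, a lower number a stronger inhibitor), compound 1 gives 569 nM, the lowest of the two numbers in hand. Among the compounds with values here, its one measured neighbour is compound 2 `CCC(C)n1ncn(-c2ccc(N3CCN(c4ccc(OC[C@@H]5CO[C@@](CN(C)C)(c6ccc(Cl)cc6Cl)O5)cc4)CC3)cc2)c1=O`, which in this assay gives 1400 nM; the step of a 2.5-fold higher number from compound 1 to compound 2 (0.39 log units; beyond the scatter) is the only measured change at the same position, and it shows a modest loss when the bromo group is exchanged.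

Compound 3 `CCC(C)n1ncn(-c2ccc(N3CCN(c4ccc(OC[C@@H]5CO[C@@](Cn6ncnn6)(c6ccc(Cl)cc6Cl)O5)cc4)CC3)cc2)c1=O` is the next variant, differing from compound 1 by 2H-tetrazol-2-yl in place of bromo on a saturated chain carbon bound to a saturated ring carbon. Within the data shown here, the entering group carries an aromatic ring where dimethylamino does not, and no measured step covers such a group; only the step of a 2.5-fold higher number from compound 1 to compound 2 (0.39 log units; beyond the scatter) bears on the change, and it suggests that swapping out the bromo group at this position tends to raise the number. Among the measured compounds shown here, a step of similar size, in the same direction, is therefore expected, with wide uncertainty since the only precedent is a single pair. For compound 3 in this assay the estimate is 1100 nM, within a range from 350 nM to 3500 nM, which means an expected step of a 1.9-fold higher number from compound 1 to compound 3 (0.29 log units; within the scatter).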

Compound 3, half-maximal inhibitory concentration: 124 nM
For compound 3 the middle estimate is 8.9-fold (0.95 log units) above the measured one; the whole stated range lies above it.
By their numbers in this assay, from the lowest: compound 3; then compound 1; then compound 2.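

In this assay, within the data shown here, the single earlier step had left open whether any exchange of the bromo group on a saturated chain carbon bound to a saturated ring carbon raises the number, but 2H-tetrazol-2-yl gives a 4.6-fold lower number from compound 1 to compound 3 (0.66 log units; beyond the scatter), so the direction of the change depends on the entering group. The two replacements are far apart, with 2H-tetrazol-2-yl in place of dimethylamino giving an 11-fold lower number from compound 2 to compound 3 (1.05 log units; beyond the scatter), which makes compound 3 the strongest inhibitor of the three and shows that this position responds strongly to what is placed there. No measurement at hand accounts for this reversal or for the size of the gap.

On these data alone, whether the result is particular to 2H-tetrazol-2-yl remains open: an imidazolyl, a triazolyl or a phenyl group on the same carbon would show how far it depends on the ring and how far on its nitrogen atoms. All three steps are also read on the core of compound 1 alone, so whether the same order of bromo, dimethylamino and 2H-tetrazol-2-yl holds on any other core cannot be said.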